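A Chlorine Added Again, on a Different Core

This account rests on a few compounds, and the source may have more. Where it says the series, first, only, none or still open, it means among the compounds named here.

Two pairs of compounds share one structural change. Compound 1 `COc1c(/C=C2/C(=O)Nc3ccccc32)c2ccccc2n1-c1ccccc1` and compound 3 `COc1c(/C=C2/C(=O)Nc3ccc(Cl)cc32)c2ccccc2n1-c1ccccc1` form the first pair; compound 2 `O=C1Nc2ccccc2/C1=C\c1c(Cl)n(CCCc2ccccc2)c2ccccc12` and compound 4 `O=C1Nc2ccc(Cl)cc2/C1=C\c1c(Cl)n(CCCc2ccccc2)c2ccccc12` form the second. The difference between the core of compound 1 and the core of compound 2 is not broken down here.

The read-out is a functional assay on NSCLC cells (Homo sapiens) for cytotoxicity, with a stated time of 48 h; on this read-out higher numbers stand for weaker inhibition of growth and lower numbers for stronger inhibition of growth. In this assay compound 1 gives 8320 nM, and compound 3 gives 24600 nM. The change between these two is chloro in place of hydrogen on an aromatic carbon and it made the step of a 3.0-fold higher number from compound 1 to compound 3 (0.47 log units; beyond the scatter). Compound 2 gives 72400 nM, the highest number among the three measured compounds, and its distance from compound 3 and from compound 1 lies beyond the usual scatter in both cases.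

Compound 4 is not yet measured. For the measured compounds named here, it differs from compound 2 by chloro in place of hydrogen on an aromatic carbon which is the same change, at the same kind of place, as the one from compound 1 to compound 3. Going by the values given here, on the single earlier instance, the step of a 3.0-fold higher number from compound 1 to compound 3 (0.47 log units; beyond the scatter), the step from compound 2 to compound 4 in this assay is expected to be about a 2.5-fold higher number from compound 2 to compound 4 (0.40 log units; beyond the scatter), with wide uncertainty since only one example supports it. Compound 4 is therefore estimated to give around 180000 nM in this assay, with a likely range from 60000 nM to 500000 nM.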

Compound 4, concentration for total growth inhibition: 8910 nM
Compound 4: middle estimate off by 20-fold (1.31 log units), on the high side; the whole stated range lies above it.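

Putting chloro in place of hydrogen on an aromatic carbon gave an 8.1-fold lower number from compound 2 to compound 4 (0.91 log units; beyond the scatter) in this assay, so on this core the change went with stronger inhibition of growth, whereas on the core of compound 1 it went with weaker inhibition. Set side by side, the two results show that the same change moved the number in opposite directions: the same change on two cores in this assay, a 3.0-fold higher number (0.47 log units; beyond the scatter) from compound 1 to compound 3 and an 8.1-fold lower number (0.91 log units; beyond the scatter) from compound 2 to compound 4, 24-fold (1.38 log units) apart, beyond the scatter of two such steps This shows that, among these compounds, the result of adding chloro on one core could not be carried over to the other core, but it does not show why, and two pairs give no rule for predicting the step on any further core.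

The compounds shown carry only hydrogen or chloro at this place, so it remains open how a fluoro group, a methoxy group or an amine on the same aromatic carbon would behave on either core. The two cores also differ in more than one place, and no compound shown separates those differences, so it remains open which part of the core goes with the change in direction.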